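The source may hold more compounds than are shown below. What is called first, only, known or untested is meant among the compounds shown, and "the series" means these compounds.

Compound 1 `Nc1ncn(Cc2c(Cl)cccc2Cl)c2ncnc1-2`: 4.71 h
Compound 2 `Nc1ncn(Cc2c(Cl)cncc2Cl)c2ncnc1-2`: 0.71 h

Both numbers come from an ADME assay on the whole organism (Mus musculus, strain C57BL/6) for metabolic stability, read by LC-MS, with a stated time of 24 h, at a dose of 10 mg/kg by the oral route; a lower number here means that the compound disappears faster, a higher number that the compound lasts longer. Of the two, compound 2 holds the lower number at 0.71 h, and compound 1 stands higher at 4.71 h, a gap beyond the scatter.

Compound 3 `Cc1ccccc1-c1nc2c(N)ncn(Cc3c(Cl)cncc3Cl)c-2n1` is compound 2 with one change: 2-methylphenyl in place of hydrogen on an aromatic carbon. Within the data shown here, no pair of measured compounds shows what such a change does, so the expectation rests on little. With compound 2 at 0.71 h, a small upward step in this assay is expected, one that stays within the scatter. The expected change is a 1.7-fold higher number from compound 2 to compound 3 (0.23 log units; within the scatter). For compound 3 the estimated half-life is 1.2 h, with an expected range of 0.4 h to 3.5 h.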

Compound 3, half-life: 1.55 h
Estimate against measurement, compound 3: 1.3-fold (0.11 log units) below; low and high end bracket the measured number.
By their numbers in this assay, from the lowest: compound 2; then compound 3; then compound 1.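

In this assay, the change at this position gives a 2.2-fold higher number from compound 2 to compound 3 (0.34 log units; beyond the scatter), a modest step but one beyond the scatter. Among these compounds, this is the first reading for this position, on an aromatic carbon between two ring nitrogen atoms: hydrogen can give way to 2-methylphenyl, with its 7 heavy atoms and six-membered aromatic ring, and the half-life does not fall but rises. Nothing measured here bears on why the number moves this way.

On these data alone, it remains open whether the methyl of the 2-methylphenyl matters, or whether a plain phenyl, a morpholine or a carboxylic acid on the same carbon would move the number in the same direction. Also open, as far as these compounds go, is whether 2-methylphenyl in place of that hydrogen would give a similar step on compound 1.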